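The source may hold more compounds than are shown below. What is called first, only, known or untested is meant among the compounds shown, and "the series" means these compounds.

Measured so far in an ADME assay on Vero cells (Chlorocebus sabaeus) for cytotoxicity; on this read-out lower numbers stand for higher toxicity in this test and higher numbers for lower toxicity in this test:
- compound 1, `COc1ccc(-c2nc3c(C(=O)Nc4cnc(Cl)cn4)cccc3[nH]2)cc1OC`: 78.3 uM
- compound 2, `COc1ccc(-c2nc3c(C(=O)NCCCO)cccc3[nH]2)c(OC)c1OC`: 40 uM

Compound 2 carries the lowest of the two numbers in this assay, yet its nearest neighbour, compound 1, sits within the scatter of it, so the two values cannot be told apart. Compound 3, `COc1ccc(-c2nc3c(C(=O)Nc4cnc(Cl)cn4)cccc3[nH]2)c(OC)c1OC`, remains to be measured in this assay. It differs from compound 2 by 5-chloropyrazin-2-yl in place of 3-hydroxypropyl on an amide-type nitrogen, the same amide substituent that compound 1 already carries. Among the compounds with values here, since no step between measured compounds is available for this exchange, only the two values give guidance: compound 1 with the chloropyrazinyl amide reads 78.3 uM, compound 2 with the hydroxypropyl amide reads 40 uM, and the gap between them is within the scatter. The step of a 1.5-fold higher number from compound 2 to compound 3 (0.18 log units; within the scatter) is therefore expected to be small, leaning towards a higher number but not beyond the scatter. Compound 3 is estimated at 60 uM, with a range from 25 uM to 150 uM.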

Compound 3, half-maximal toxic concentration: 65.2 uM
Compound 3: middle estimate off by 1.1-fold (0.04 log units), on the low side; measured number inside the range.
By their numbers in this assay, from the lowest: compounds 2, 3 and 1 (each within the scatter of the next).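

In this assay, within the data shown here, 5-chloropyrazin-2-yl in place of 3-hydroxypropyl on the amide-type nitrogen gives the first direct reading of this exchange (a 1.6-fold higher number from compound 2 to compound 3 (0.21 log units; within the scatter)), and the two compounds cannot be told apart. Methoxy in place of hydrogen on an aromatic carbon gives a second single-place reading (a 1.2-fold lower number from compound 1 to compound 3 (0.08 log units; within the scatter)), which also stays within the scatter, so neither change separates its pair on this read-out. No accompanying measurement bears on these two results.

Going by these compounds, whether an amine, a carboxylic acid or a longer chain on the amide-type nitrogen would give a step beyond the scatter remains open. Also open, on these data alone, is whether methoxy in place of hydrogen reads the same when the amide-type nitrogen carries 3-hydroxypropyl.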